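This account rests on a few compounds, and the source may have more. Where it says the series, first, only, none or still open, it means among the compounds named here.

Measured so far: compound 2 `COc1cc(COc2cc(N)c(Cl)cc2C(=O)CCCCN2CCC(NC(N)=O)CC2)cc(OC)c1` with 8.5 in a functional assay for antagonist activity at 5-hydroxytryptamine receptor 4 (Rattus norvegicus) (a higher number here means a more potent compound, by a factor of ten per unit of this negative logarithm, a lower number a less potent compound), and compound 1 `COc1cc(COc2cc(N)c(Cl)cc2C(=O)CCCCN2CCC(OC)CC2)cc(OC)c1` with 8.4.

Compound 2 sits together with compound 1 on the numbers shown; the step of a number 0.10 log units higher from compound 1 to compound 2 (within the scatter) is within the scatter. Compound 3 `COc1cc(COc2cc(N)c(Cl)cc2C(=O)CCCCN2CCC(NS(C)(=O)=O)CC2)cc(OC)c1` is not yet measured. It differs from compound 2 by methylsulfonyl in place of carbamoyl on an amine nitrogen. Going by the values given here, only the step from compound 1 to compound 2 bears on this site, and it was small, so no step beyond the scatter is expected. The expected step is a number 0.10 log units lower from compound 2 to compound 3 (within the scatter). Compound 3 is estimated at 8.4 in this assay, in the range 7.9 to 8.9.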

Compound 3, negative logarithm of the antagonist equilibrium constant: 8.4
Compound 3: middle estimate and measured number agree at the digits printed, within the range that was stated.
By their numbers in this assay, from the lowest: compounds 1, 3 and 2 (each within the scatter of the next).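

In this assay the change from ureido to methanesulfonamido reads a number 0.10 log units lower from compound 2 to compound 3 (within the scatter) and the change from methoxy to methanesulfonamido reads no change at the digits printed from compound 1 to compound 3 (within the scatter) so methylsulfonyl on the amine nitrogen serves here as carbamoyl does. This saturated ring carbon has now carried three different groups with no step beyond the scatter. Nothing measured on these compounds gives a reason for this.

Open, as far as these compounds go, is whether a primary amine, a carboxylic acid or a longer chain on this ring carbon would stay within the same narrow band. Also open, from the compounds shown here alone, is whether a ring carbon bearing only hydrogen would do so.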